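The source may hold more compounds than are shown below. What is called first, only, known or untested is meant among the compounds shown, and "the series" means these compounds.

Working notes on the series. Within the data shown here, compound 2 `CCNC(=O)Nc1ccc(S(=O)(=O)Oc2ccccc2C(C)C)cc1` gives in a functional assay on MCF7 cells (Homo sapiens) for antiproliferative activity, read by sulforhodamine B assay, with a stated time of 48 h (on this read-out lower numbers stand for stronger inhibition and higher numbers for weaker inhibition), a value of 10000 nM, the higher of the two numbers measured so far; its nearest neighbour, compound 1 `CC(C)C(=O)Nc1ccc(S(=O)(=O)Oc2ccccc2C(C)C)cc1`, gives 8600 nM in this assay, and the step of a 1.2-fold higher number from compound 1 to compound 2 (0.07 log units; within the scatter) stays within the scatter. Compound 3 `CC(C)c1ccccc1OS(=O)(=O)c1ccc(NC(=O)NCC2CCCC2)cc1` differs from compound 2 by cyclopentyl in place of methyl on a saturated chain carbon bound to an amide-type nitrogen. Among the measured compounds shown here, no measured step touches that chain carbon; the single measured step exchanges the group on the carbonyl carbon and is itself within the scatter, so it only shows that this end of the shared core tolerated one change without effect. With nothing pointing in either direction, compound 3 is expected to land close to compound 2, with a step of a 1.1-fold lower number from compound 2 to compound 3 (0.05 log units; within the scatter) that is not expected to exceed the scatter. Compound 3 is therefore estimated at 9000 nM in this assay, within a range from 3500 nM to 25000 nM.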

Compound 3, half-maximal inhibitory concentration: 7100 nM
Compound 3: the middle estimate sits 1.3-fold (0.10 log units) above what was measured, within the range that was stated.
By their numbers in this assay, from the lowest: compounds 3, 1 and 2 (each within the scatter of the next).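

In this assay, cyclopentyl in place of methyl on a saturated chain carbon bound to an amide-type nitrogen gives a 1.4-fold lower number from compound 2 to compound 3 (0.15 log units; within the scatter) and so shows that this position, untouched by the earlier step, takes a five-membered non-aromatic ring of carbon without a shift beyond the scatter. On the carbonyl carbon, (cyclopentylmethyl)amino in place of isopropyl gives a 1.2-fold lower number from compound 1 to compound 3 (0.08 log units; within the scatter) and adds a second change at this end of the shared core that stays within the scatter. No available evidence bears on this result.

The compounds shown leave open whether an amine or a carboxylic acid on this chain, or a longer chain such as hexyl, would move the number beyond the scatter. They also leave open whether any change elsewhere on the shared core would do so.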